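The source may hold more compounds than are shown below. What is called first, only, known or untested is meant among the compounds shown, and "the series" means these compounds.

Working notes on the series. In a functional assay on M21 cells (Homo sapiens) for cytotoxicity, read by sulforhodamine B assay, with a stated time of 48 h (a higher number here means a weaker inhibitor, a lower number a stronger inhibitor), compound 1 `Cc1ccccc1OS(=O)(=O)c1cccc(NC(=O)NCCCCl)c1` gives 29000 nM. Compound 2 `Cc1ccccc1OS(=O)(=O)c1ccc(NC(=O)NCCCCl)cc1` gives 25000 nM, and this value lies within the scatter of the value for compound 1, so the numbers do not separate the two compounds.

The next compound is compound 3 `O=C(NCCCCl)Nc1ccc(S(=O)(=O)Oc2ccc(O)cc2)cc1`, not yet measured in this assay. Its difference from compound 2 is 4-hydroxyphenyl in place of 2-methylphenyl on an oxygen. In words, this is 4-hydroxyphenyl in place of 2-methylphenyl on an oxygen, with the rest of the structure unchanged.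

Among the measured compounds shown here, no measured pair differs in one place only, so the data offer no direct guide to this exchange. For the measured compounds named here, the only anchor is compound 2 at 25000 nM, and a large move away from it has no support in the data. The estimated step is a 1.4-fold higher number from compound 2 to compound 3 (0.15 log units; within the scatter), which is expected to stay within the scatter, with a slight lean toward a higher number. For compound 3 the estimated value is 35000 nM, with an expected range from 12000 nM to 90000 nM.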

Compound 3, half-maximal inhibitory concentration: 47000 nM
Estimate against measurement, compound 3: 1.3-fold (0.13 log units) below, and the stated range covers the measured number.
By their numbers in this assay, from the lowest: compounds 2, 1 and 3 (each within the scatter of the next).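

In this assay, among the compounds shown here, the exchange on the oxygen whose other neighbour is the sulfonyl sulfur gives a 1.9-fold higher number from compound 2 to compound 3 (0.27 log units; within the scatter), the first step that differs in one place only. At this position, 4-hydroxyphenyl in place of 2-methylphenyl therefore does not separate the two compounds, even though the entering group carries a hydrogen-bond donor and a hydrogen-bond acceptor that the leaving group lacks and both groups have the same number of heavy atoms. No measurement bearing on the reason for this result is at hand, so the step stands as an observation only.

The compounds shown leave open whether a different group on this oxygen, such as a phenyl ring bearing an amine or a carboxylic acid, or a longer alkyl chain in place of the ring, would give a step beyond the scatter. They also leave open how the loss of the methyl and the gain of the hydroxyl each contribute, which a plain phenyl on this oxygen could help to separate.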